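An Aromatic Ring Replaces Ethyl on the Nitrogen

The source may report more compounds than this note shows. Statements on the series, on what has been measured and on what is new or still open speak of the compounds shown alone.

In a functional assay on NCI-H460 cells (Homo sapiens) for cytotoxicity, read by MTT assay, with a stated time of 3 days (on this read-out higher numbers stand for weaker inhibition and lower numbers for stronger inhibition), compound 2 (`CCNc1nc(SCc2nc3ccccc3[nH]2)nc(-c2ccccc2)c1C#N`) gives 2.87 nM and stands within the scatter of compound 1 (`N#Cc1c(Nc2ccccc2)nc(SCc2nc3ccccc3[nH]2)nc1-c1ccccc1`) at 4.54 nM on the same read-out. Compound 3 (`N#Cc1c(Nc2ccccn2)nc(SCc2nc3ccccc3[nH]2)nc1-c1ccccc1`) has pyridin-2-yl in place of ethyl on a nitrogen on an aromatic ring. For the measured compounds named here, the one measured step at that place (a 1.6-fold lower number from compound 1 to compound 2 (0.20 log units; within the scatter)) put ethyl in place of phenyl and stayed within the scatter, so no step beyond the scatter is expected in this assay here. The expected change is a 1.6-fold higher number from compound 2 to compound 3 (0.20 log units; within the scatter) and stays within the scatter. Compound 3 is estimated at 4.5 nM (range 1.5 nM to 13 nM).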

Compound 3, half-maximal inhibitory concentration: 2.8 nM
Beside the measured number, compound 3's estimate is 1.6-fold (0.21 log units) above it, and the stated range covers the measured number.
By their numbers in this assay, from the lowest: compounds 3, 2 and 1 (each within the scatter of the next).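

Pyridin-2-yl in place of ethyl on a nitrogen on an aromatic ring gives a 1.0-fold lower number from compound 2 to compound 3 (0.01 log units; within the scatter) in this assay, and pyridin-2-yl in place of phenyl gives a 1.6-fold lower number from compound 1 to compound 3 (0.21 log units; within the scatter). Ethyl, phenyl and pyridin-2-yl thus all stand within the scatter of one another at this place, and the ring nitrogen that separates pyridin-2-yl from phenyl brings no step beyond it. No evidence is available to explain this result. From the compounds shown here alone, whether a carboxylic acid or a longer chain on this nitrogen would also stay within the scatter remains open.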